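A few compounds are considered here, and "the series" means these few. Any claim that something is new, unique, unknown or untested is made for them only; others in the source may bear on it.

Measured so far:
Compound 1 `O=C(C1=C(OC2CCCCC2)C(=O)N(CCCn2ccnc2)C1c1ccc(Br)cc1)c1ccccc1` — in a functional assay on U2OS cells (Homo sapiens) for antiproliferative activity, read by MTT assay, with a stated time of 72 h (on this read-out lower numbers stand for stronger inhibition and higher numbers for weaker inhibition), compound 1 gives 22400 nM.
Compound 2 `O=C(C1=C(Nc2ccccc2)C(=O)N(CCCn2ccnc2)C1c1ccc(Br)cc1)c1ccccc1` — in this assay compound 2 gives 25700 nM.

Going by the values given here, compound 2 stands alongside compound 1, the only measured step being a 1.1-fold higher number from compound 1 to compound 2 (0.06 log units; within the scatter), so the two cannot be told apart. Compound 3 `O=C(C1=C(Nc2cccc(Br)c2)C(=O)N(CCCn2ccnc2)C1c1ccc(Br)cc1)c1ccccc1` differs from compound 2 by bromo in place of hydrogen on an aromatic carbon, on the anilino ring. Among the compounds with values here, no measured step bears on this change; the one step recorded concerns another group and stayed within the scatter. Compound 3 is therefore expected to give a step of a 1.2-fold lower number from compound 2 to compound 3 (0.07 log units; within the scatter) that does not exceed the scatter. The estimate for compound 3 in this assay is 22000 nM, with a range from 8000 nM to 60000 nM.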

Compound 3, half-maximal inhibitory concentration: 11900 nM
Estimate against measurement, compound 3: 1.8-fold (0.27 log units) above, and the stated range covers the measured number.
By their numbers in this assay, from the lowest: compounds 3, 1 and 2 (each within the scatter of the next, the first and the last beyond it).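

Bromo in place of hydrogen on the anilino ring, on an aromatic carbon meta to a large group, gives the first step in this assay to pass the scatter, though a modest one (a 2.2-fold lower number from compound 2 to compound 3 (0.33 log units; beyond the scatter)). Set against the cyclohexyloxy group, the (3-bromophenyl)amino group stays within the scatter (a 1.9-fold lower number from compound 1 to compound 3 (0.27 log units; within the scatter)). No evidence is available to account for the bromo step. On these data alone, whether chloro, methoxy or a nitrile on the same ring would give a similar step remains open. So does whether bromo on another carbon of that ring would.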